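Moving the fluorine on the phenyl ring of compound 3

The source may hold more compounds than are shown below. What is called first, only, known or untested is meant among the compounds shown, and "the series" means these compounds.

Compound 3, `CC(C(=O)N1CCN(c2ccc(F)cc2)CC1)N1C(=O)CCC1=O`, is the best performer of the three compounds measured in a functional assay on the whole organism (strain Swiss) with Mus musculus as the target, in the maximal electroshock model, with a stated time of 0.25 h, at a dose of 100 mg/kg by the intraperitoneal route; on this read-out lower numbers stand for a weaker effect and higher numbers for a stronger effect at the one dose given: compound 3 gives 75%. Compound 1, `CCC(C(=O)N1CCN(c2cccc(Cl)c2)CC1)N1C(=O)CCC1=O`, gives 50%, and compound 2, `COc1cccc(N2CCN(C(=O)C(C)N3C(=O)CCC3=O)CC2)c1`, gives 25%. Among the compounds with values here, the only measured step that alters a single part of the molecule runs a number 50 percentage points higher from compound 2 to compound 3 (beyond the scatter), where 4-fluorophenyl replaced 3-methoxyphenyl on an amine nitrogen in a ring.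

Compound 4, `CC(C(=O)N1CCN(c2cccc(F)c2)CC1)N1C(=O)CCC1=O`, is built from the same atoms as compound 3 but arranged differently: 3-fluorophenyl in place of 4-fluorophenyl on an amine nitrogen in a ring. Within the data shown here, no measured pair isolates this change, since the step from compound 2 to compound 3 swapped both the kind of substituent and where it sits. The halogen stays a fluorine, so the reshuffle is smaller than any step measured here, yet the two compounds carrying a substituent at the 3-position of the phenyl ring, compound 1 and compound 2, both fall well short of compound 3. The expected move is therefore downward, a number 25 percentage points lower from compound 3 to compound 4 (beyond the scatter). Compound 4 is estimated to reach 50%, within a range from 25% to 75%.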

Compound 4, a percentage reported as activity, at one dose (the size of the read-out at that dose, not a potency): 75%
Beside the measured number, compound 4's estimate is 25 percentage points below it, and the stated range covers the measured number.
By their numbers in this assay, from the lowest: compound 2; then compound 1; then compounds 3 and 4 (each within the scatter of the next).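

In this assay, moving the fluorine around the phenyl ring gives no change at the digits printed from compound 3 to compound 4 (within the scatter), so 4-fluorophenyl and 3-fluorophenyl cannot be told apart on this core at the one dose given. The earlier step from compound 2 to compound 3 changed both the kind of group and its place, but compound 2 and compound 4 both carry their group at the same place on the ring, and fluoro in place of methoxy gives a number 50 percentage points higher from compound 2 to compound 4 (beyond the scatter). Within this set, then, the kind of group matters here and its place does not, and compound 4 shows that a group at that place does not by itself bring a low number.

Nothing shown here explains why fluoro and methoxy part so widely on this read-out. Also open, on these data alone, is whether a trifluoromethyl group or a nitrile on the same phenyl ring would hold the number reached by the two fluorine compounds, and whether compound 3 and compound 4 would stay level at other doses.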